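The source may hold more compounds than are shown below. What is called first, only, known or untested is meant among the compounds shown, and "the series" means these compounds.

Measured so far, in an ADME assay on blood (Homo sapiens) for pharmacokinetics; a higher number here means that the compound lasts longer, a lower number that the compound disappears faster:
Compound 1 `CCc1cc(C(=O)OCO[P@@]2(=O)OCC(C)(C)[C@H](C(=O)NCCC(=O)OC)O2)n(C)n1` gives >= 0.97 h, a limit of the assay.
Compound 2 `COC(=O)CCNC(=O)[C@@H]1OP(=O)(Oc2ccc(F)cc2)OCC1(C)C` gives > 1 h, also a limit.
Compound 3 `CC(C)(C)C(=O)OCO[P@@]1(=O)OCC(C)(C)[C@H](C(=O)NCCC(=O)OCCc2ccccn2)O1` gives < 0.16 h, a limit at the short end.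

Compound 1 thus stands only at a limit, (the limit of >= 0.97 h in this assay, at which 1 of the 3 values shown sits), with no number attached. Compound 2 sits at the limit of > 1 h in this assay, at which 1 of the 3 values shown sits. Compound 3 sits at the limit of < 0.16 h in this assay, at which 1 of the 3 values shown sits. Among the measured compounds shown here, compound 1 is therefore grouped with compound 2 at the long-lived end and apart from compound 3; no single-change step between measured compounds exists, so no step size is known.

Compound 4 `COC(=O)CCNC(=O)[C@@H]1O[P@@](=O)(OCOC(=O)c2scnc2C(C)(C)C)OCC1(C)C` differs from compound 1 in one place: 4-(tert-butyl)-1,3-thiazol-5-yl in place of 3-ethyl-1-methyl-1H-pyrazol-5-yl on a carbonyl carbon. In this assay the step from compound 1 to compound 4 is expected to be none beyond the scatter, in either direction. The expected step is a step that the limit leaves unreadable from compound 1 to compound 4. Compound 4 is estimated at 1 h, with a range from 0.4 h to 2.5 h.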

Compound 4, half-life: > 1 h
Compound 4: a limit, no number; the forecaster's own chance of this, stated with the estimate: 45%; the middle value lies on the limit itself.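

In this assay, among the compounds shown here, compound 1 and compound 4 both stand at limits, so no step between them can be read. The compounds shown leave open whether 4-(tert-butyl)-1,3-thiazol-5-yl and 3-ethyl-1-methyl-1H-pyrazol-5-yl differ at all in half-life.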